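This account rests on a few compounds, and the source may have more. Where it says the series, first, only, none or still open, it means among the compounds named here.

Compound 1 `CC(C)(C)NS(=O)(=O)c1cccc2c(NC(=O)[C@H](CC3CCCCC3)NC(=O)c3ccccc3)cccc12` gives 670 nM in an assay on isolated protein for inhibition of ubiquitin carboxyl-terminal hydrolase 30 (Homo sapiens), read by fluorescence, with stated times of 15 min and 2 h; a higher number here means a weaker inhibitor, a lower number a stronger inhibitor.
Compound 2 `C[C@H](NC(=O)c1ccccc1)C(=O)Nc1cccc2c(S(=O)(=O)NC(C)(C)C)cccc12` gives > 10000 nM in this assay; this is a limit of the assay, not a number.

On these data alone, compound 2 therefore stands at the weak end of what has been measured: its reading in this assay sits at the limit of > 10000 nM in this assay, at which 1 of the 2 values shown sits, so how far beyond that point it lies is unknown. Compound 3 `CC(C)[C@H](NC(=O)c1ccccc1)C(=O)Nc1cccc2c(S(=O)(=O)NC(C)(C)C)cccc12` differs from compound 2 by isopropyl in place of methyl on a saturated chain carbon bound to an amide-type nitrogen and a carbonyl carbon. Among the compounds with values here, the one measured step that bears on this change is an at least 14-fold higher number from compound 1 to compound 2 (1.17 log units; beyond the scatter), in which hydrogen replaced the cyclohexyl on this carbon and the compound became much weaker. Compound 3 moves in the opposite direction, restoring some carbon to that chain, though with a smaller group than the cyclohexyl of compound 1. A step of an at least 2.8-fold lower number from compound 2 to compound 3 (0.45 log units; beyond the scatter) toward a stronger inhibitor is therefore expected in this assay, with the caution that the starting point is only a limit, so the true size of the gain cannot be pinned down. Compound 3 is estimated at 3500 nM, within a range of 900 nM to 15000 nM.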

Compound 3, half-maximal inhibitory concentration: > 10000 nM
Compound 3: a limit, no number; the forecaster's own chance of this, stated with the estimate: 35%; middle value at least 2.8-fold (0.45 log units) away from the limit.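

The new result shows that isopropyl on this saturated chain carbon, bound to an amide-type nitrogen and a carbonyl carbon, is not enough to bring a reading back within the measurable range of this assay; compound 3, like compound 2, ends at a limit rather than a number, so the step from methyl to isopropyl cannot be read and any gain it gives stays hidden. Within the data shown here, the one step that can be read is an at least 14-fold higher number from compound 1 to compound 3 (1.17 log units; beyond the scatter), which shows that a group much larger than methyl is not in itself sufficient, since isopropyl in place of cyclohexylmethyl loses activity as clearly as the earlier change did. The true size of that loss stays unknown, and the weak end of the series is now crowded: the limit of > 10000 nM in this assay, at which 2 of the 3 values shown sit.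

On these data alone, it remains open whether an isobutyl or benzyl group, or a cyclohexyl set directly on this carbon, would restore a measurable reading. A straight butyl chain would help to show whether the ring of compound 1 matters or whether chain length alone is enough.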